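This account rests on a few compounds, and the source may have more. Where it says the series, first, only, none or still open, it means among the compounds named here.

Measured so far:
compound 1 `CCCCCOc1ccc(C(=O)c2cccc(Cn3ccnc3)c2)cc1`: 42 nM
compound 2 `C#CCOc1ccc(C(=O)c2cccc(Cn3ccnc3)c2)cc1`: 650 nM

Both were run in an assay on isolated protein for inhibition of Aromatase (Homo sapiens), read by fluorescence, with stated times of 10 min and 60 min; a lower number here means a stronger inhibitor, a higher number a weaker inhibitor. For the measured compounds named here, compound 2 stands at the higher of the two numbers, with compound 1 as its only neighbour at the far end of the single step of a 15-fold higher number from compound 1 to compound 2 (1.19 log units; beyond the scatter). Compound 3 `CCC#CCOc1ccc(C(=O)c2cccc(Cn3ccnc3)c2)cc1` is not yet measured; it differs from compound 2 by ethyl in place of hydrogen on a triple-bonded carbon, so that propargyloxy becomes (pent-2-yn-1-yl)oxy. Going by the values given here, the only step that bears on it is a 15-fold higher number from compound 1 to compound 2 (1.19 log units; beyond the scatter), where butyl gave way to ethynyl and the number rose steeply. Compound 3 moves back along that same line, though a triple bond remains in the chain, so a lower number is expected, without the whole of the earlier step being recovered. For compound 3 the expected step is a 4.3-fold lower number from compound 2 to compound 3 (0.64 log units; beyond the scatter) and the value is estimated at 150 nM, within 60 nM to 400 nM.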

Compound 3, half-maximal inhibitory concentration: 9 nM
Estimate against measurement, compound 3: 17-fold (1.22 log units) above; measured number below the stated range.
By their numbers in this assay, from the lowest: compound 3; then compound 1; then compound 2.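

In this assay ethyl on the triple-bonded carbon gives a 72-fold lower number from compound 2 to compound 3 (1.86 log units; beyond the scatter) and so a triple bond in the chain does not by itself account for the high number of compound 2. What stands on the far side of the triple bond counts heavily at this position: the but-1-yn-1-yl arrangement also improves on the saturated butyl, with a 4.7-fold lower number from compound 1 to compound 3 (0.67 log units; beyond the scatter) as the step, and the earlier 15-fold higher number from compound 1 to compound 2 (1.19 log units; beyond the scatter) no longer reads as a cost of the triple bond alone. Nothing measured here gives a reason for the size of these steps.

From the compounds shown here alone, whether the gain continues past ethyl remains open, for instance with propyl or a longer chain on the triple-bonded carbon. Also open, going by these compounds, is how an amine or a hydroxyl at the chain end would read against the plain ethyl.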